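The source may hold more compounds than are shown below. What is called first, only, known or untested is meant among the compounds shown, and "the series" means these compounds.

Measured compounds:
Compound 1 `COC(=O)[C@@]1(C)CCC=C2[C@@H]1CC[C@@H](C)[C@]2(C)Cc1c[nH]c2ccc(C)cc12` — 22000 nM
Compound 2 `COC(=O)[C@@]1(C)CCC=C2[C@@H]1CC[C@@H](C)[C@]2(C)Cc1c[nH]c2ccc(Br)cc12` — 20000 nM
Compound 3 `COC(=O)[C@@]1(C)CC[C@@H]2C3=C1CC[C@@H](C)[C@]3(C)C[C@@H]1c3cc(C)ccc3N[C@H]21` — 32000 nM

All three values come from a functional assay on WiDr cells (Homo sapiens) for inhibition, read by sulforhodamine B assay, with a stated time of 48 h (on this read-out lower numbers stand for stronger inhibition of growth and higher numbers for weaker inhibition of growth), and lie within the scatter of one another. Going by the values given here, the one change made twice is bromo in place of methyl on an aromatic carbon: from compound 1 to compound 2 it is bromo in place of methyl on an aromatic carbon, and in this assay it gave a 1.1-fold lower number from compound 1 to compound 2 (0.04 log units; within the scatter). The difference between the core of compound 1 and the core of compound 3 is not broken down here; the two have the same atoms joined differently.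

Compound 4 `COC(=O)[C@@]1(C)CC[C@@H]2C3=C1CC[C@@H](C)[C@]3(C)C[C@@H]1c3cc(Br)ccc3N[C@H]21` carries the same kind of change relative to compound 3, (bromo in place of methyl on an aromatic carbon). The surroundings are not identical: in compound 3 the ring is part of a fused or bridged system of five rings, in compound 1 of two rings. Because the earlier step was a 1.1-fold lower number from compound 1 to compound 2 (0.04 log units; within the scatter), a step of about a 1.1-fold lower number from compound 3 to compound 4 (0.04 log units; within the scatter) is expected here, within the scatter. For compound 4 the estimate in this assay is 29000 nM, likely between 15000 nM and 60000 nM.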

Compound 4, concentration for 50% growth inhibition: 55000 nM
Compound 4: the middle estimate sits 1.9-fold (0.28 log units) below what was measured, within the range that was stated.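

In this assay, bromo in place of methyl on an aromatic carbon gave a 1.7-fold higher number from compound 3 to compound 4 (0.24 log units; within the scatter). Set beside the earlier step, the change carries from one core to the other with no gap that can be told from the scatter: the same change on two cores in this assay, a 1.1-fold lower number (0.04 log units; within the scatter) from compound 1 to compound 2 and a 1.7-fold higher number (0.24 log units; within the scatter) from compound 3 to compound 4, 1.9-fold (0.28 log units) apart, within the scatter of two such steps. This rests on one pair per core, and both steps lie within the scatter, so it does not show that the change alters growth inhibition on either core, or that the agreement would hold on a further core.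

Still open, going by these compounds, is how a group other than methyl or bromo would read on the same aromatic carbon, such as an amine or a longer chain. Also open, on these data alone, is what a carboxylic acid in place of the methyl ester would give on either core.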